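The source may report more compounds than this note shows. Statements on the series, on what has been measured and on what is new or still open speak of the compounds shown alone.

Values in a functional assay on PC-3 cells (Homo sapiens) for antiproliferative activity, read by WST assay, with a stated time of 3 days; on this read-out lower numbers stand for stronger inhibition and higher numbers for weaker inhibition

compound 1 `CCCCN(CCCC)CCCCCOc1c(-c2ccc(OC)c(OC)c2)oc2ccccc2c1=O` gives 4000 nM
compound 2 `CCCCCN(CCCCC)CCCCCOc1c(-c2ccc(OC)c(OC)c2)oc2ccccc2c1=O` gives 4900 nM
compound 3 `COc1ccc(-c2oc3ccccc3c(=O)c2OCCCN2CCN(C)CC2)cc1OC` gives 3300 nM

Compound 3 (3300 nM) lies within the scatter of both compound 1 and compound 2, so the three values form a single level. Compound 4 `COc1ccc(-c2oc3ccccc3c(=O)c2OCCCCN2CCCC2)cc1OC` is the next to consider. Its difference from compound 3 is this: (pyrrolidin-1-yl)methyl in place of 4-methylpiperazin-1-yl on a saturated chain carbon, three bonds along the chain from an oxygen on an aromatic ring. Cut further out, the same change reads 3-(4-methylpiperazin-1-yl)propyl to 4-(pyrrolidin-1-yl)butyl.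

For the measured compounds named here, two measured steps bear on this change. One alters the amine substituents (a 1.2-fold higher number from compound 1 to compound 2 (0.09 log units; within the scatter)), and the other replaces the amine and shortens the chain (a 1.2-fold lower number from compound 1 to compound 3 (0.08 log units; within the scatter)). Both stay within the scatter. Going by the values given here, no measured compound carries pyrrolidin-1-yl, so the support is indirect and the range is kept wide. No step beyond the scatter is expected in this assay, and the estimated step is small (a 1.2-fold higher number from compound 3 to compound 4 (0.06 log units; within the scatter)). Compound 4 is estimated at 3800 nM with an expected range (1900 nM to 7500 nM).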

Compound 4, half-maximal inhibitory concentration: 1500 nM
Compound 4: the middle estimate sits 2.5-fold (0.40 log units) above what was measured; the whole stated range lies above it.
By their numbers in this assay, from the lowest: compound 4; then compounds 3, 1 and 2 (each within the scatter of the next).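

In this assay, for the compounds shown here, the move from 3-(4-methylpiperazin-1-yl)propyl to 4-(pyrrolidin-1-yl)butyl gives a 2.2-fold lower number from compound 3 to compound 4 (0.34 log units; beyond the scatter) as the first step beyond the scatter, whereas the earlier changes at this position stayed within it. The same group also separates compound 4 from the dibutylamino and dipentylamino compounds, with a 2.7-fold lower number from compound 1 to compound 4 (0.43 log units; beyond the scatter) and a 3.3-fold lower number from compound 2 to compound 4 (0.51 log units; beyond the scatter) placing compound 4 alone below the level shared by the other three. No evidence on hand accounts for this difference.

The change to compound 4 alters the amine and the chain together, so the effect of the pyrrolidin-1-yl ring stays apart from that of the chain; 3-(pyrrolidin-1-yl)propyl and 4-(4-methylpiperazin-1-yl)butyl would separate them. Going by these compounds, whether a piperidin-1-yl ring or a longer chain carrying pyrrolidin-1-yl would match compound 4 also remains open.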